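This account rests on a few compounds, and the source may have more. Where it says the series, first, only, none or still open, it means among the compounds named here.

Measured in a functional assay on MM1.S cells (Homo sapiens) for inhibition, read by WST assay, with a stated time of 4 days; on this read-out higher numbers stand for weaker inhibition and lower numbers for stronger inhibition:

- Compound 1 `CC(C)(C)c1ccc(CN2CCN(S(=O)(=O)Nc3ccc(SCCc4ccccc4)cc3C(=O)O)CC2)cc1`: 32600 nM
- Compound 2 `CCC(=O)N1CCN(c2c3ccc(-c4cccc(F)c4)cc3nn2Cc2ccccc2)CC1`: 16800 nM

In this assay, compound 2 gives 16800 nM and compound 1 gives 32600 nM, so the two lie within the usual scatter of each other. Neither stands apart, and their structures share little. Compound 3 `C=CC(=O)N1CCN(c2c3ccc(-c4cccc(F)c4)cc3nn2Cc2ccccc2)CC1` keeps all of compound 2 except at one place, with vinyl in place of ethyl on a carbonyl carbon. The change adds one double bond outside aromatic rings and leaves the count of heavy atoms as it was. Among the compounds with values here, no measured pair shows this change, which makes the expectation a judgement from the structures, anchored on compound 2 at 16800 nM. A moderate move toward stronger inhibition, beyond the scatter, is expected, and the estimated step is a 4.2-fold lower number from compound 2 to compound 3 (0.62 log units; beyond the scatter). The estimate for compound 3 is 4000 nM, with an expected range of 800 nM to 18000 nM.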

Compound 3, half-maximal inhibitory concentration: 6800 nM
For compound 3 the middle estimate is 1.7-fold (0.23 log units) below the measured one; measured number inside the range.
By their numbers in this assay, from the lowest: compound 3; then compounds 2 and 1 (each within the scatter of the next).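

In this assay, within the data shown here, vinyl in place of ethyl on a carbonyl carbon gives a 2.5-fold lower number from compound 2 to compound 3 (0.39 log units; beyond the scatter), the only step here that can be read between compounds differing in one place. It shows that this position, on a carbonyl carbon whose other neighbour is an amide-type nitrogen in a ring, responds beyond the scatter to a modest change that keeps the count of heavy atoms and adds one double bond outside aromatic rings. No measurement at hand accounts for the step.

The compounds shown leave open how a longer chain such as butanoyl, or an acyl group carrying an amine such as dimethylaminoacetyl, would compare with vinyl at this position. They also leave open whether the same step would appear on a different core.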